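Aryl terminus exchanged for a tris-hydroxymethyl semicarbazide end group

The source may hold more compounds than are shown below. What is called first, only, known or untested is meant among the compounds shown, and "the series" means these compounds.

Two members of the series have been run in a physicochemical assay for inhibition, read by spectrophotometry, tested at 100 uM; a lower number here means less inhibition, a higher number more inhibition at the concentration tested (going by the name of the read-out). Compound 1 `COc1ccc(C(=NNC(=O)NNC(=O)NCCCC(C)Nc2cc(OC)cc3cccnc23)c2ccc(OC)cc2)cc1` gives 82%, and compound 2 `COc1cc(NC(C)CCCNC(=O)Nc2ccc(Cl)c(C(F)(F)F)c2)c2ncccc2c1` gives 61%, the lower of the two numbers, a gap beyond the usual scatter. Compound 3 `COc1cc(NC(C)CCCNC(=O)NNC(=O)NC(CO)(CO)CO)c2ncccc2c1` is the next member; it differs from compound 2 by ((2-hydroxy-1,1-bis(hydroxymethyl)ethyl)carbamoyl)amino in place of 4-chloro-3-(trifluoromethyl)phenyl on an amide-type nitrogen. Among the compounds with values here, no step between measured compounds covers such a change, so the direction is open. A moderate fall is expected from compound 2 to compound 3, a number 16 percentage points lower from compound 2 to compound 3 (beyond the scatter), in this assay. Compound 3 is estimated at 45%, with a range from 20% to 70%.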

Compound 3, a percentage reported as inhibition, at one concentration (the size of the read-out at that concentration, not a potency): 49%
The estimate for compound 3 lay 4 percentage points below the measured number, and the stated range covers the measured number.
By their numbers in this assay, from the lowest: compound 3; then compound 2; then compound 1.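

On an amide-type nitrogen, ((2-hydroxy-1,1-bis(hydroxymethyl)ethyl)carbamoyl)amino in place of 4-chloro-3-(trifluoromethyl)phenyl gives a number 12 percentage points lower from compound 2 to compound 3 (beyond the scatter) in this assay. With no ring in this end group, compound 3 still gives 49%, so an aromatic ring at this position is not required for a measurable read-out at the concentration tested. Nothing at hand explains the fall.

This single exchange does not separate the loss of the aryl ring from the entry of the hydroxymethyl groups. Where an unsubstituted phenyl or a simple hydroxyethyl group on the same nitrogen would fall remains open.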